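Pyridine halogen pattern on the sulfonamide nitrogen: compound 4

This account rests on a few compounds, and the source may have more. Where it says the series, first, only, none or still open, it means among the compounds named here.

Measured in an assay on HEK293 cells for inhibition of solute carrier family 22 member 12 (Homo sapiens); a lower number here means a stronger inhibitor, a higher number a weaker inhibitor:
compound 1, `O=S(=O)(CSc1nnc(Br)n1Cc1ccc(Br)c2ccccc12)Nc1cncc(C(F)(F)F)c1`: 6380 nM
compound 2, `O=S(=O)(CSc1nnc(Br)n1Cc1ccc(Br)c2ccccc12)Nc1cc(Cl)cnc1Cl`: 2790 nM
compound 3, `O=S(=O)(CSc1nnc(Br)n1Cc1ccc(Br)c2ccccc12)Nc1ccc(Br)nc1Br`: 5410 nM

Compound 3 sits second highest of the three numbers in this assay. Its nearest neighbour is compound 1, with a 1.2-fold lower number from compound 1 to compound 3 (0.07 log units; within the scatter) separating them; the largest gap is to compound 2, a 1.9-fold higher number from compound 2 to compound 3 (0.29 log units; within the scatter). Within the data shown here, the only change beyond the scatter in the whole set is a 2.3-fold lower number from compound 1 to compound 2 (0.36 log units; beyond the scatter).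

Compound 4, `O=S(=O)(CSc1nnc(Br)n1Cc1ccc(Br)c2ccccc12)Nc1ccc(Br)nc1`, differs from compound 3 in one place: hydrogen in place of bromo on an aromatic carbon. Among the measured compounds shown here, no measured pair isolates the loss of a single bromo; the three measured steps all exchange one halogenated pyridinyl for another, and two of them stay within the scatter. On that record no step beyond the scatter is expected for compound 4 in this assay, with a wide range allowed. The step of a 1.1-fold higher number from compound 3 to compound 4 (0.04 log units; within the scatter) is the working estimate. For compound 4 a value of about 6000 nM is expected, between 2500 nM and 15000 nM.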

Compound 4, half-maximal inhibitory concentration: 2200 nM
The estimate for compound 4 lay 2.7-fold (0.44 log units) above the measured number; measured number below the stated range.
By their numbers in this assay, from the lowest: compounds 4, 2, 3 and 1 (each within the scatter of the next, the first and the last beyond it).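

In this assay the change from 2,6-dibromopyridin-3-yl to 6-bromopyridin-3-yl gives a step beyond the scatter (a 2.5-fold lower number from compound 3 to compound 4 (0.39 log units; beyond the scatter)), so the bromo next to the ring nitrogen is not required for inhibition in this set, and its replacement by hydrogen is tolerated. The 6-bromopyridin-3-yl group of compound 4, which carries a single halogen, stays within the scatter of the 2,5-dichloropyridin-3-yl group (a 1.3-fold lower number from compound 2 to compound 4 (0.10 log units; within the scatter)) and lies beyond it against the 5-(trifluoromethyl)pyridin-3-yl group (a 2.9-fold lower number from compound 1 to compound 4 (0.46 log units; beyond the scatter)). No measurement at hand explains the step.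

Open, on these data alone, is whether hydrogen itself matters here or only the absence of bromo, which a fluoro, methyl or amine on that carbon would test. As far as these compounds go, the part played by the remaining bromo also stays open.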